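Long-chain carbamate and urea triacids: cytotoxicity in epithelial cells

A few compounds are considered here, and "the series" means these few. Any claim that something is new, unique, unknown or untested is made for them only; others in the source may bear on it.

Measured so far:
Compound 1, `CCCCCCCCCCCCCCCCCCCCCCOC(=O)NC(CCC(=O)O)(CCC(=O)O)CCC(=O)O`, gives 360000 nM in an ADME assay on cells (Epithelial cell, Homo sapiens) for cytotoxicity, read by MTT assay; a lower number here means that less compound is needed, a higher number that more compound is needed for the effect.
Compound 3, `CCCCCCCCCCCCCCOC(=O)NC(CCC(=O)O)(CCC(=O)O)CCC(=O)O`, gives 620000 nM in this assay.
Compound 2, `CCCCCCCCCCCCCCNC(=O)NC(CCC(=O)O)(CCC(=O)O)CCC(=O)O`, is reported as "not determined" (no result reported) in this assay, so no number is available for it.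

Compounds 1 and 3 share a carbamate core carrying three carboxylic acid arms and differ only by octyl in place of hydrogen on a saturated chain carbon, ten or more bonds along the chain from an oxygen next to a carbonyl group. That step, a 1.7-fold lower number from compound 3 to compound 1 (0.24 log units; within the scatter), is small and within the usual scatter, so lengthening the chain left the read-out essentially unchanged.

Compound 4, `CCCCCCCCCCCCCCCCCCCCCCNC(=O)NC(CCC(=O)O)(CCC(=O)O)CCC(=O)O`, is the unmeasured member. It stands to compound 2 as compound 1 stands to compound 3: the difference is octyl in place of hydrogen on a saturated chain carbon, ten or more bonds along the chain from an amide-type nitrogen. The place differs in its surroundings, an amide-type nitrogen rather than an oxygen next to a carbonyl group, so this is the same kind of change, not the same one. How the urea core of compound 2 differs from the carbamate core of compound 3 is not broken down here, and compound 2 itself gives no number to anchor on.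

The expectation for compound 4 therefore rests on compound 1 at 360000 nM and compound 3 at 620000 nM, the two cores being close relatives. Compound 4 is expected to give about 400000 nM, estimated between 150000 nM and 1000000 nM.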

Compound 4, half-maximal effective concentration: 260000 nM
Compound 4: middle estimate off by 1.5-fold (0.19 log units), on the high side; low and high end bracket the measured number.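

Within the data shown here, compound 2 has no number in this assay, so no step from compound 2 to compound 4 can be read. The compounds shown leave open whether octyl in place of hydrogen does the same on the core of compound 2 as on the core of compound 3. No measured evidence bears on the result for compound 4.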